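The source may report more compounds than this note shows. Statements on the series, on what has been measured and on what is new or still open speak of the compounds shown alone.

Measured so far in an ADME assay on L6 cells (Rattus norvegicus) for cytotoxicity, read by resazurin assay, with a stated time of 72 h; on this read-out higher numbers stand for weaker inhibition and lower numbers for stronger inhibition:
- compound 1 `NC1CC2(N3CCCC3)CC(c3ccccc3)C1C(c1ccccc1)C2` gives 38100 nM
- compound 2 `CCN(CC)CC(=O)OC1CC2(N(C)C)CC(c3ccccc3)C1C(c1ccccc1)C2` gives 30100 nM
- compound 3 `CCN(CC)CC(=O)OC1CC2(N3CCCCC3)CC(c3ccccc3)C1C(c1ccccc1)C2` gives 23900 nM

Not yet measured: compound 4 `CCN(CC)CC(=O)OC1CC2(N3CCCC3)CC(c3ccccc3)C1C(c1ccccc1)C2`

Compound 3, at 23900 nM in this set, lies within the scatter of both other compounds, so the three values cannot be ranked. The next change keeps the (((diethylamino)methyl)carbonyl)oxy group and puts pyrrolidin-1-yl in place of piperidin-1-yl on a saturated ring carbon to give compound 4.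

Going by the values given here, one measured step bears directly on this place. Putting piperidin-1-yl in place of dimethylamino gives a 1.3-fold lower number from compound 2 to compound 3 (0.10 log units; within the scatter) and so shows no clear response to exchanging the group there. Compound 1 also carries pyrrolidin-1-yl and gives 38100 nM in this assay, but it lacks the (((diethylamino)methyl)carbonyl)oxy group and is only a loose guide. No step beyond the scatter is therefore expected in this assay, in either direction. The expected change is a 1.1-fold higher number from compound 3 to compound 4 (0.04 log units; within the scatter) and no real shift is implied by it. Compound 4 is estimated at 26000 nM, with an expected range from 14000 nM to 45000 nM.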

Compound 4, half-maximal inhibitory concentration: 49000 nM
The estimate for compound 4 lay 1.9-fold (0.28 log units) below the measured number, outside the stated range (above it).
By their numbers in this assay, from the lowest: compounds 3, 2, 1 and 4 (each within the scatter of the next, the first and the last beyond it).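

In this assay, going by these compounds alone, this saturated ring carbon now shows a response to the exchange of its amine, as pyrrolidin-1-yl in place of piperidin-1-yl gives the first step beyond the scatter, though a modest one (a 2.1-fold higher number from compound 3 to compound 4 (0.31 log units; beyond the scatter)). The response is not general to this place, since pyrrolidin-1-yl in place of dimethylamino stays within the scatter (a 1.6-fold higher number from compound 2 to compound 4 (0.21 log units; within the scatter)), and so does the earlier step from dimethylamino to piperidin-1-yl; among these three groups, only the pair of piperidin-1-yl and pyrrolidin-1-yl is separated, and only narrowly. With pyrrolidin-1-yl held, (((diethylamino)methyl)carbonyl)oxy in place of amino also stays within the scatter (a 1.3-fold higher number from compound 1 to compound 4 (0.11 log units; within the scatter)), so that exchange shows no clear response here.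

No measurement available here accounts for the step between the two rings.

The compounds shown leave open whether the step from piperidin-1-yl to pyrrolidin-1-yl persists when amino replaces the (((diethylamino)methyl)carbonyl)oxy group. They also leave open how a morpholin-4-yl or azepan-1-yl ring on this carbon would read, and so whether ring size or the ring's atoms matter at all.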